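Adding a double bond to compound 3

The source may hold more compounds than are shown below. What is called first, only, known or untested is meant among the compounds shown, and "the series" means these compounds.

Compound 3 (`CC(C)C(c1ccc(-c2ccc3cccc(F)c3c2)[nH]c1=O)C1SC(=O)NC1=O`) has the higher of the two numbers available in an ADME assay on MDCK cells (Canis lupus familiaris) for permeability, in the apical to basolateral direction; a higher number here means that the compound crosses the layer faster, a lower number that the compound crosses the layer more slowly: compound 3 reaches 26.3 10^-6 cm/s, while compound 1 (`CC(C)C(/C=C1\NC(=O)NC1=O)c1ccc(-c2ccc3cccc(F)c3c2)[nH]c1=O`) gives 12.3 10^-6 cm/s. For compound 2 (`CC(C)C(c1ccc(-c2ccc3cccc(F)c3c2)[nH]c1=O)C1NC(=O)NC1=O`) the entry reads "not determined" (no result reported).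

The change that leads to compound 4 (`CC(C)C(/C=C1\SC(=O)NC1=O)c1ccc(-c2ccc3cccc(F)c3c2)[nH]c1=O`) is this: a group of 8 heavy atoms (4 carbon, 1 nitrogen, 2 oxygen, 1 sulfur; one five-membered non-aromatic ring with 2 hetero atoms) in place of a group of 7 heavy atoms (3 carbon, 1 nitrogen, 2 oxygen, 1 sulfur; one five-membered non-aromatic ring with 2 hetero atoms), on a saturated chain carbon bound to an aromatic carbon and a saturated chain carbon. The 2,4-dioxo-1,3-thiazolidin-5-yl group leaves, and the group that enters has one more double bond outside aromatic rings.

For the measured compounds named here, only one measured step bears on this, and only indirectly: a 2.1-fold higher number from compound 1 to compound 3 (0.33 log units; beyond the scatter). This modest step alters the make-up of the ring and also removes that extra double bond, so it cannot separate the two changes. Compound 2 and compound 1 differ by the same double bond, but without a number for compound 2 that comparison stays empty.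

Compound 4 shares its ring with compound 3 and its extra double bond with compound 1, so a number inside the span of these two compounds is expected: compound 3 gives 26.3 10^-6 cm/s and compound 1 gives 12.3 10^-6 cm/s. The expected change is small and downward, a 1.4-fold lower number from compound 3 to compound 4 (0.14 log units; within the scatter), and not beyond the scatter.

Compound 4 is estimated at 19 10^-6 cm/s, with an expected range of 9 10^-6 cm/s to 38 10^-6 cm/s.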

Compound 4, apparent permeability: 15.4 10^-6 cm/s
The estimate for compound 4 lay 1.2-fold (0.09 log units) above the measured number; low and high end bracket the measured number.
By their numbers in this assay, from the lowest: compounds 1, 4 and 3 (each within the scatter of the next, the first and the last beyond it).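

With the sulfur-containing ring held constant, the extra double bond can now be read on its own in this assay: it gives a 1.7-fold lower number from compound 3 to compound 4 (0.23 log units; within the scatter). With that double bond held constant, the ring make-up can also be read on its own, and the exchange of one ring nitrogen for sulfur gives a 1.3-fold higher number from compound 1 to compound 4 (0.10 log units; within the scatter), so neither change alone moves the number beyond the scatter, although the two together, in a 2.1-fold higher number from compound 1 to compound 3 (0.33 log units; beyond the scatter), do. Nothing available here explains why these numbers take the values they do.

From the compounds shown here alone, the pair of compound 1 and compound 2 gives no reading, so it remains open whether the double bond would have a similarly small effect on the ring containing two nitrogens. Going by these compounds, it also remains open how the number would respond if the five-membered ring gave way to a group of a different kind at this position, such as a carboxylic acid or an amine on the saturated chain carbon.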